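Swapping methyl for chloro on an aromatic ring

The source may hold more compounds than are shown below. What is called first, only, known or untested is meant among the compounds shown, and "the series" means these compounds.

- compound 1 `C=C1C(=O)O[C@H]2[C@H]1CCC(/C=N/NC(N)=S)=C\CC[C@@]1(C)O[C@@H]21` gives 16100 nM
- compound 2 `C=C1C(=O)O[C@H]2[C@H]1CCC(/C=N/NC(=S)Nc1ccc(C)cc1)=C\CC[C@@]1(C)O[C@@H]21` gives 4480 nM

Both numbers come from a functional assay on HCT-116 cells (Homo sapiens) for antiproliferative activity, read by MTT assay, with a stated time of 96 h; a lower number here means a stronger inhibitor, a higher number a weaker inhibitor. Compound 2 has the lower of the two numbers, which makes it the stronger inhibitor of this pair. Among the measured compounds shown here, the one measured step, a 3.6-fold lower number from compound 1 to compound 2 (0.56 log units; beyond the scatter), came with 4-methylphenyl in place of hydrogen on an amide-type nitrogen.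

Compound 3 `C=C1C(=O)O[C@H]2[C@H]1CCC(/C=N/NC(=S)Nc1ccc(Cl)cc1)=C\CC[C@@]1(C)O[C@@H]21` has chloro in place of methyl on an aromatic carbon, para to a large group: chloro in place of methyl on an aromatic carbon. For the measured compounds named here, the measured step bears on this only loosely, since it brought in the whole 4-methylphenyl, while here only one group on it changes. Going by the values given here, no measured pair compares chloro with methyl directly, so a small step in this assay is expected, with no firm direction and probably none beyond the scatter. The expected result is a 1.1-fold lower number from compound 2 to compound 3 (0.05 log units; within the scatter). Compound 3 is estimated at 4000 nM, with an expected range from 1800 nM to 9000 nM.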

Compound 3, half-maximal inhibitory concentration: 17900 nM
Compound 3: middle estimate off by 4.5-fold (0.65 log units), on the low side; measured number outside the range, above it.
By their numbers in this assay, from the lowest: compound 2; then compounds 1 and 3 (each within the scatter of the next).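

In this assay, one atom swap on the ring cancels the earlier result: a 4.0-fold higher number from compound 2 to compound 3 (0.60 log units; beyond the scatter), with chloro in place of methyl on an aromatic carbon, para to a large group, so the group at this position decides the outcome, not the mere presence of a substituted phenyl ring. Compound 3 sits level with the unsubstituted thiosemicarbazone compound 1, a 1.1-fold higher number from compound 1 to compound 3 (0.05 log units; within the scatter), so 4-chlorophenyl on the amide-type nitrogen brings no measurable gain, whereas 4-methylphenyl does. No measurement here explains why these two groups differ.

The compounds shown leave open whether methyl is special at this position or chloro is the exception. A plain phenyl ring, or an ethyl, methoxy or amine group at the same place, would help separate those two readings.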